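The source may report more compounds than this note shows. Statements on the series, on what has been measured and on what is new or still open speak of the compounds shown alone.

Measured in a functional assay on BXPC-3 cells (Homo sapiens) for antiproliferative activity, read by MTT assay, with a stated time of 24 h; on this read-out lower numbers stand for stronger inhibition and higher numbers for weaker inhibition:

- Compound 1 `CCn1c(C(=O)NCCC(=O)OC)ccc1C(CC)(CC)c1ccc(OCS(=O)(=O)c2ccccc2)c(C)c1`: > 50000 nM, a limit of the assay and not a number
- Compound 2 `CCN(CC)CCNC(=O)c1ccc(C(CC)(CC)c2ccc(OCS(=O)(=O)c3ccccc3)c(C)c2)n1CC`: 6270 nM
- Compound 3 `CCn1c(C(=O)NC(C)(C)CO)ccc1C(CC)(CC)c1ccc(OCS(=O)(=O)c2ccccc2)c(C)c1`: 18300 nM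

Among the measured compounds shown here, only two of these values are true numbers. Compound 3, at 18300 nM, holds the higher of the two, which makes it the weaker inhibitor of that pair. The gap is a 2.9-fold higher number from compound 2 to compound 3 (0.47 log units; beyond the scatter). Compound 1 carries only a limit, so the comparison with it gives a bound, not an exact size: an at least 2.7-fold lower number from compound 1 to compound 3 (0.43 log units; beyond the scatter).

Compound 4 `CCn1c(C(=O)N[C@H](CO)C(C)C)ccc1C(CC)(CC)c1ccc(OCS(=O)(=O)c2ccccc2)c(C)c1` changes compound 3 in one place, on an amide-type nitrogen: 1-(hydroxymethyl)-2-methylpropyl in place of 1-(hydroxymethyl)-1-methylethyl on an amide-type nitrogen. The hydroxymethyl stays in the group, and the change is one of 1-methylethyl to 2-methylpropyl naming, with a defined stereocentre entering.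

Both steps above were made on this same nitrogen, and both were modest or, for the bound, at least modest. They replaced a whole 2-(diethylamino)ethyl or 2-(methoxycarbonyl)ethyl group, a larger swap than this one. Judging from the size of a 2.9-fold higher number from compound 2 to compound 3 (0.47 log units; beyond the scatter), a smaller change is expected here, probably none beyond the scatter, with a slight lean towards a lower number. The expected step is a 1.3-fold lower number from compound 3 to compound 4 (0.12 log units; within the scatter). For compound 4 the estimated value is 14000 nM, with an expected range of 5000 nM to 40000 nM.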

Compound 4, half-maximal inhibitory concentration: 7720 nM
Compound 4: middle estimate off by 1.8-fold (0.26 log units), on the high side, and the stated range covers the measured number.
By their numbers in this assay, from the lowest: compounds 2 and 4 (each within the scatter of the next); then compound 3. At a limit, above all of these: compound 1.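

In this assay, a small change on the amide-type nitrogen moves the number beyond the scatter: a 2.4-fold lower number from compound 3 to compound 4 (0.37 log units; beyond the scatter). Among the compounds shown here, this swap of 1-(hydroxymethyl)-2-methylpropyl for 1-(hydroxymethyl)-1-methylethyl keeps the hydroxymethyl and the count of one hydrogen-bond donor and one acceptor, so the earlier exchanges of whole groups are no longer the only changes here with a step beyond the scatter. Compound 4 also stands level with compound 2, which carries the 2-(diethylamino)ethyl group (a 1.2-fold higher number from compound 2 to compound 4 (0.09 log units; within the scatter)), and compound 1 holds a limit of the assay and not a number, so an at least 6.4-fold lower number from compound 1 to compound 4 (0.81 log units; beyond the scatter) is only a bound: the limit of > 50000 nM in this assay, at which 1 of the 4 values shown sits.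

The step from compound 3 to compound 4 adds one carbon and one defined stereocentre together, and the compounds shown cannot tell which of the two goes with the lower number. Also open, from the compounds shown here alone, are the opposite stereocentre, a longer chain on the same nitrogen, and a carboxylic acid or an amine in place of the hydroxymethyl.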